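A few compounds are considered here, and "the series" means these few. Any claim that something is new, unique, unknown or untested is made for them only; others in the source may bear on it.

Measured so far in an ADME assay (liver) for metabolic stability, with Liver microsome (Homo sapiens) as the target, read by LC-MS, using microsomes and NADPH, tested at 1 uM; a higher number here means that the compound lasts longer, a lower number that the compound disappears faster:

- compound 1, `CC(C)(C)c1cc(NC(=O)[C@@H]2CCCCN2Cc2ccc(Cl)cc2)no1`: 0.15 h
- compound 2, `CC(C)CN1CCCC[C@H]1C(=O)Nc1cc(C(C)(C)C)on1`: 0.1 h
- compound 3, `CC(C)(C)c1cc(NC(=O)[C@@H]2CCCCN2C(=O)c2ccc(Cl)cc2)no1`: 1.25 h

Compound 3 gives the highest of the three numbers in this assay. The nearest is compound 1, and the gap is an 8.3-fold higher number from compound 1 to compound 3 (0.92 log units; beyond the scatter); the furthest is compound 2, with a 13-fold higher number from compound 2 to compound 3 (1.10 log units; beyond the scatter). Between compound 1 and compound 2 the difference is a 1.5-fold lower number from compound 1 to compound 2 (0.18 log units; within the scatter).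

Compound 4, `CC(C)(C)c1cc(NC(=O)[C@@H]2CCCCN2C(=O)C2CCOCC2)no1`, keeps the acyl group on the ring nitrogen that separates compound 3 from the other two, and changes the group on the carbonyl carbon: oxan-4-yl in place of 4-chlorophenyl on a carbonyl carbon. Neither measured step bears directly on this change. The steps from compound 1 and compound 2 to compound 3 both alter what sits on the ring nitrogen, and both are beyond the scatter; they say nothing about swapping an aromatic ring for a saturated one on the carbonyl carbon. Compound 4 retains the feature shared with compound 3, so its number is expected to stay nearer compound 3 than compound 1 or compound 2, with the step from compound 3 to compound 4 estimated as a 1.6-fold lower number from compound 3 to compound 4 (0.19 log units; within the scatter), of uncertain direction.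

For compound 4 the estimate in this assay is 0.8 h, expected to fall between 0.3 h and 2.5 h.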

Compound 4, half-life: > 2 h
Compound 4: no number, only a limit (the forecaster's own chance of this, stated with the estimate: 5%); middle value at least 2.5-fold (0.39 log units) away from the limit.
By their numbers in this assay, from the lowest: compounds 2 and 1 (each within the scatter of the next); then compound 3. At a limit, above all of these: compound 4.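

Compound 4 stands at a limit of this assay, not at a number: the limit of > 2 h in this assay, at which 1 of the 4 values shown sits. For the compounds shown here, on a carbonyl carbon whose other neighbour is the amide-type nitrogen in a ring, the earlier compounds showed only 4-chlorophenyl, and the step to oxan-4-yl reads an at least 1.6-fold higher number from compound 3 to compound 4 (0.20 log units; that floor lies within the scatter), so an aromatic ring of carbon only is not required to reach this range, though the true size of the step stays unknown. The two steps from the compounds without a carbonyl on the ring nitrogen, an at least 13-fold higher number from compound 1 to compound 4 (1.12 log units; beyond the scatter) and an at least 20-fold higher number from compound 2 to compound 4 (1.30 log units; beyond the scatter), show that the large gap seen with compound 3 also holds with a second group on that carbonyl.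

On these data alone, how far compound 4 actually stands from compound 3 remains open. So does whether a piperidin-4-yl, an amine in the ring in place of the oxygen, or an open chain such as isobutyl on the same carbonyl carbon would stay in this range.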